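Series Notes: Step from Compound 2 to Compound 4

The compounds below may be only part of what the source reports. "The series", "measured", "known", "first", "only" and "open" are said of these compounds alone.

Three compounds carry numbers in an assay for inhibition of Indoleamine 2,3-dioxygenase 1 (Homo sapiens), read by spectrophotometry, with a stated time of 180 min, tested at 10 uM; on this read-out higher numbers stand for a stronger effect at the one concentration tested and lower numbers for a weaker effect. Compound 1 `Oc1ccc(CNc2cc(Br)cc3[nH]ncc23)cc1` gives 70% in this assay, the highest of the three. Compound 2 `Cc1ccc(CNc2cc(Br)cc3[nH]ncc23)cc1` gives 20% in this assay, the second highest of three numbers; its nearest neighbour is compound 3 `O=C(O)c1ccc(CNc2cccc3[nH]ncc23)cc1`, which gives 1% in this assay, a gap beyond the scatter, and its furthest is compound 1, also beyond the scatter. Among the measured compounds shown here, the one step that ends at compound 2 is a number 50 percentage points lower from compound 1 to compound 2 (beyond the scatter), the change being methyl in place of hydroxy on an aromatic carbon.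

Compound 4 `Brc1cc(NCc2ccccc2)c2cn[nH]c2c1` is not yet measured in this assay. It differs from compound 2 by hydrogen in place of methyl on an aromatic carbon.

For the measured compounds named here, no measured step removes a methyl, so nothing bears directly on this change. The step from compound 1 to compound 2 shows that the group at this place can shift the number strongly, but it exchanges hydroxy for methyl, not methyl for hydrogen, and compound 3 differs in two places from compound 2 and gives no clean comparison. The expectation is therefore a small step or none beyond the scatter, leaning lower, and the expected step is a number 6 percentage points lower from compound 2 to compound 4 (within the scatter). Compound 4 is estimated at 14% in this assay, within 0% to 40%.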

Compound 4, a percentage reported as inhibition, at one concentration (the size of the read-out at that concentration, not a potency): 37%
Compound 4: middle estimate off by 23 percentage points, on the low side; the range from low to high includes it.
By their numbers in this assay, from the lowest: compound 3; then compound 2; then compound 4; then compound 1.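

Hydrogen now serves as a reference at this place, on the aromatic carbon para to a large group, and methyl does not behave as a neutral stand-in for it in this assay: there is a number 17 percentage points higher from compound 2 to compound 4 (beyond the scatter). Against the same reference, hydroxy also stands apart, with a number 33 percentage points lower from compound 1 to compound 4 (beyond the scatter), so the earlier exchange of hydroxy for methyl can now be read in two parts, and the three groups rank hydroxy, then hydrogen, then methyl, each gap beyond the scatter. No measurement on hand accounts for this order.

Going by these compounds, what a methoxy group, an amine or a carboxylic acid would give at this same place on the core of compound 4 stays open, so three groups fix the order but do not show which feature of hydroxy goes with the higher number. All of these numbers also come from one concentration, which leaves open whether the same order would hold for potency or with a group other than bromine on the core.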